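Adding a Phenyl Group to a Weak Sulfone Compound

This account rests on a few compounds, and the source may have more. Where it says the series, first, only, none or still open, it means among the compounds named here.

Measured so far in an assay on isolated protein for inhibition of 3',5'-cyclic-AMP phosphodiesterase 4A (Cavia porcellus), read by cAMP accumulation, tested at 10 uM; a lower number here means a weaker effect, a higher number a stronger effect of the compound at the concentration tested:
compound 1, `O=C1CC(c2ccccc2)Cc2[nH]c(=O)c(C(=O)c3ccccc3)cc21`, gives 5.2%
compound 2, `O=C1CCCc2[nH]c(=O)c(S(=O)(=O)c3ccccc3)cc21`, gives 0%

Both measured compounds share a core in which a ketone and a lactam sit on fused rings; they differ in the group on the lactam ring, a benzoyl in compound 1 and a phenylsulfonyl in compound 2, and in the phenyl on the saturated ring carried only by compound 1. Compound 2 has the lower of the two numbers, but compound 1 lies close enough that the two values cannot be told apart with confidence. Neither compound shows much effect at the concentration tested.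

Compound 3, `O=C1CC(c2ccccc2)Cc2[nH]c(=O)c(S(=O)(=O)c3ccccc3)cc21`, is not yet measured. It keeps the phenylsulfonyl group of compound 2 and differs from it in one place: phenyl in place of hydrogen on a saturated ring carbon. Among the compounds with values here, no pair of measured compounds differs in just this one place, so the size of this step is unknown here. Both measured compounds give low numbers, so the step from compound 2 to compound 3 is expected to be small, a number 4 percentage points higher from compound 2 to compound 3 (within the scatter), with no direction beyond the scatter. Compound 3 is therefore estimated at 4%, within 0% to 15%.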

Compound 3, a percentage reported as inhibition, at one concentration (the size of the read-out at that concentration, not a potency): 0%
Estimate against measurement, compound 3: 4 percentage points above; low and high end bracket the measured number.
By their numbers in this assay, from the lowest: compounds 2, 3 and 1 (each within the scatter of the next).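

In this assay, within the data shown here, phenyl in place of hydrogen on a saturated ring carbon gives no change at the digits printed from compound 2 to compound 3 (within the scatter) and so provides the first direct reading of this position. With the phenylsulfonyl group in the compound, this added ring makes no difference that can be told from the scatter at the concentration tested. The other single change, phenylsulfonyl in place of benzoyl on an aromatic carbon, gives a number 5.2 percentage points lower from compound 1 to compound 3 (within the scatter) and also stays inside the scatter, and no measurement here offers an explanation for either result.

From the compounds shown here alone, all three compounds give low numbers at this one concentration, so it remains open whether an amine or a carboxylic acid on the added phenyl, or a longer chain in its place on the saturated ring carbon, would produce a clear effect. Also open, going by these compounds, is how the same step from hydrogen to phenyl would read in a compound carrying benzoyl rather than phenylsulfonyl on the aromatic carbon.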